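Swapping a nitro for a trifluoromethyl on an ester-linked aryl ring

A few compounds are considered here, and "the series" means these few. Any claim that something is new, unique, unknown or untested is made for them only; others in the source may bear on it.

Measured so far:
compound 1, `COc1cccc(C(=O)Oc2cc3c(cc2C)[C@@H](C(C)C)CC=C3C)c1`: "not active" (no number reported)
compound 2, `CC1=CC[C@H](C(C)C)c2cc(C)c(OC(=O)c3ccc([N+](=O)[O-])cc3)cc21`: 16.8%

Both compounds share a bicyclic core carrying an isopropyl group and a methyl, with an aromatic ester attached to the same position of that core; they differ only in the substituent on the ester's aryl ring. Among the measured compounds shown here, in a functional assay on U-251 cells (Homo sapiens) for antiproliferative activity, read by sulforhodamine B assay, with a stated time of 48 h, tested at 50 uM (on this read-out higher numbers stand for more inhibition at the one concentration tested (going by the name of the read-out) and lower numbers for less inhibition), compound 2 gives 16.8%, which is the only number available here, since compound 1 is reported as "not active" (no number reported) with no number given. For the measured compounds named here, compound 2 therefore provides the only inhibition number at the single concentration tested.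

Compound 3, `CC1=CC[C@H](C(C)C)c2cc(C)c(OC(=O)c3ccc(C(F)(F)F)cc3)cc21`, keeps everything of compound 2 except for one change: trifluoromethyl in place of nitro on an aromatic carbon.

Going by the values given here, no pair of measured compounds separated by a single change is available, so there is no guide to the size of such a step. The expectation is a step from compound 2 to compound 3 of a number 1.8 percentage points lower from compound 2 to compound 3 (within the scatter), that is, none beyond the usual scatter. Compound 3 is estimated at 15%, with a range from 0% to 35%.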

Compound 3, a percentage reported as inhibition, at one concentration (the size of the read-out at that concentration, not a potency): 14.7%
Compound 3: the middle estimate sits 0.3 percentage points above what was measured, within the range that was stated.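

In this assay the exchange of trifluoromethyl for nitro at this carbon, para to a large group, gives a number 2.1 percentage points lower from compound 2 to compound 3 (within the scatter) and so leaves the two compounds indistinguishable on this read-out. Among the compounds shown here, this is the first direct comparison at this position, and it shows that the inhibition seen for compound 2 does not depend on nitro specifically: a group with a different set of atoms and no hydrogen-bond acceptors, where nitro has two, gives a value within the same scatter. No measurement shown here accounts for this likeness between the two groups, so the comparison describes what happens without explaining it.

The compounds shown leave open whether a quite different group on this aromatic carbon, such as an amine or a carboxylic acid, would give a step beyond the scatter, in either direction. They also leave open how a plain hydrogen at this position would compare, which would show whether nitro and trifluoromethyl contribute anything at all to the inhibition.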